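Replacing 4-Methoxypyridin-2-yl with Acetyl in Compound 4

A few compounds are considered here, and "the series" means these few. Any claim that something is new, unique, unknown or untested is made for them only; others in the source may bear on it.

Compound 1 `O=C(CCCCCCc1ccccc1)c1ncc(-c2ccc([N+](=O)[O-])cc2)o1` — in an assay (Rattus norvegicus) for inhibition of Fatty-acid amide hydrolase 1 (Homo sapiens) (on this read-out lower numbers stand for stronger inhibition and higher numbers for weaker inhibition), compound 1 gives 50 nM
Compound 2 `NC(=O)c1ccc(-c2cnc(C(=O)CCCCCCc3ccccc3)o2)cc1` — in this assay compound 2 gives 10 nM
Compound 3 `COc1ccnc(-c2cnc(C(=O)CCCCCCc3ccccc3)o2)c1` — in this assay compound 3 gives 0.8 nM

Compound 3 gives the lowest number of the three. Its nearest neighbour is reached by a 13-fold lower number from compound 2 to compound 3 (1.10 log units; beyond the scatter) and its furthest by a 63-fold lower number from compound 1 to compound 3 (1.80 log units; beyond the scatter). Compound 4 `CC(=O)c1cnc(C(=O)CCCCCCc2ccccc2)o1` differs from compound 3 by acetyl in place of 4-methoxypyridin-2-yl on an aromatic carbon. Both measured steps into compound 3 bear on this position and were large, showing that the group on this aromatic carbon moves the number strongly. Acetyl has no ring and fewer atoms than any group measured there, so compound 4 is expected to give a higher number in this assay, a step of a 38-fold higher number from compound 3 to compound 4 (1.57 log units; beyond the scatter). Compound 4 is estimated at 30 nM, within 6 nM to 150 nM.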

Compound 4, inhibition constant: 2 nM
For compound 4 the middle estimate is 15-fold (1.18 log units) above the measured one; the measured number lies below the stated range.
By their numbers in this assay, from the lowest: compound 3; then compound 4; then compound 2; then compound 1.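

In this assay, a ring on this aromatic carbon turns out not to be needed for a low number: with acetyl in place of 4-methoxypyridin-2-yl there is only a 2.5-fold higher number from compound 3 to compound 4 (0.40 log units; beyond the scatter), a modest step. Acetyl also outdoes both other aromatic groups, with a 5.0-fold lower number from compound 2 to compound 4 (0.70 log units; beyond the scatter) and a 25-fold lower number from compound 1 to compound 4 (1.40 log units; beyond the scatter), so the ringless group ranks behind only compound 3. No measurement given here accounts for this result. The compounds shown leave open whether an amine, a carboxylic acid or a longer chain on this carbon would also give a low number.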